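The source may report more compounds than this note shows. Statements on the series, on what has been measured and on what is new or still open speak of the compounds shown alone.

Compound 1 `CCC(C)(C)Cc1c[nH]c(CCc2ccc(-c3cccc(C)n3)cc2)n1`: 106 nM
Compound 2 `CCC(C)(C)Cc1c[nH]c(CCc2ccc(-n3ncnn3)cc2)n1`: 99 nM

Both numbers come from a functional assay on HEK293 cells for agonist activity at Bombesin receptor subtype-3 (Mus musculus), read by luminescence and calcium flux, with a stated time of 10 min; a lower number here means that less compound is needed, a higher number that more compound is needed for the effect. Compound 2 stands at the low end of these two numbers, but the two cannot be told apart. Compound 3 `CCC(C)(C)Cc1c[nH]c(CCc2ccc(-c3ccccc3C(=O)O)cc2)n1` is not yet measured; it differs from compound 2 by 2-carboxyphenyl in place of 2H-tetrazol-2-yl on an aromatic carbon. Among the measured compounds shown here, only one measured step changes this same position: a 1.1-fold lower number from compound 1 to compound 2 (0.03 log units; within the scatter), which did not move the number beyond the scatter. On that basis a step from compound 2 to compound 3 of no clear direction is expected, a 1.5-fold higher number from compound 2 to compound 3 (0.18 log units; within the scatter). Compound 3 is therefore estimated at 150 nM, within a range of 40 nM to 600 nM.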

Compound 3, half-maximal effective concentration: 94 nM
Beside the measured number, compound 3's estimate is 1.6-fold (0.20 log units) above it, and the stated range covers the measured number.
By their numbers in this assay, from the lowest: compounds 3, 2 and 1 (each within the scatter of the next).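

This position takes a third, quite different group with no clear shift in this assay, with a 1.1-fold lower number from compound 2 to compound 3 (0.02 log units; within the scatter) and a 1.1-fold lower number from compound 1 to compound 3 (0.05 log units; within the scatter) both within the scatter. The 2-carboxyphenyl group brings a hydrogen-bond donor, absent from the 2H-tetrazol-2-yl group, yet compound 3 cannot be told apart from compound 2 or compound 1. No measurement at hand explains why these numbers agree. On these data alone, it remains open whether a plain phenyl ring, an amine or a short alkyl chain at this position would move the number beyond the scatter.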